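The source may hold more compounds than are shown below. What is called first, only, known or untested is meant among the compounds shown, and "the series" means these compounds.

Compound 1 `CC1=C/C(=C\C(C)C)C(=O)C(C)(O)C12CC2` gives 130 nM in a functional assay on A-375 cells (Homo sapiens) for antiproliferative activity; on this read-out lower numbers stand for stronger inhibition and higher numbers for weaker inhibition.
Compound 2 `CC1=C/C(=C\c2ccccc2)C(=O)C(C)(O)C12CC2` gives only a limit, > 10000 nM, in this assay.
Compound 3 `CC1=C/C(=C\Cl)C(=O)C(C)(O)C12CC2` gives 1000 nM in this assay.

Among the measured compounds shown here, of the two actual numbers, compound 3 holds the higher one; its nearest neighbour is set by a 7.7-fold higher number from compound 1 to compound 3 (0.89 log units; beyond the scatter), and the only other value is a limit, (the limit of > 10000 nM in this assay, at which 1 of the 3 values shown sits). All three substituents sit on the same chain carbon, and the spread across them is wide: an at least 76-fold higher number from compound 1 to compound 2 (1.88 log units; beyond the scatter), while an at least 10-fold lower number from compound 2 to compound 3 (1.00 log units; beyond the scatter).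

Compound 4 `CC1=C/C(=C\C#CCCO)C(=O)C(C)(O)C12CC2` is the next member: 4-hydroxybut-1-yn-1-yl in place of chloro on a double-bonded chain carbon bound to a double-bonded ring carbon. The measured steps that bear on this change are the ones at that same chain carbon, where chloro and isopropyl both gave numbers and phenyl gave only a limit. The new group is neither small like chloro nor a ring like phenyl, so the measured steps point in no single direction, and the account therefore expects the step of a 1.3-fold lower number from compound 3 to compound 4 (0.10 log units; within the scatter) to stay within the usual scatter. In this assay compound 4 is expected to give about 800 nM. The range for compound 4 is estimated to run from 150 nM to 5000 nM.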

Compound 4, half-maximal inhibitory concentration: 2000 nM
Compound 4: the middle estimate sits 2.5-fold (0.40 log units) below what was measured; measured number inside the range.
By their numbers in this assay, from the lowest: compound 1; then compounds 3 and 4 (each within the scatter of the next). At a limit, above all of these: compound 2.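

In this assay, replacing chloro with the larger 4-hydroxybut-1-yn-1-yl group on the double-bonded chain carbon makes no change that can be told from the scatter: a 2.0-fold higher number from compound 3 to compound 4 (0.30 log units; within the scatter). The new group also shows that the heavy loss seen with phenyl does not follow every larger substituent here, an at least 5.0-fold lower number from compound 2 to compound 4 (0.69 log units; beyond the scatter), although neither group reaches isopropyl, a 15-fold higher number from compound 1 to compound 4 (1.19 log units; beyond the scatter). Compound 2 stands at a limit and not at a number: the limit of > 10000 nM in this assay, at which 1 of the 4 values shown sits.

On these data alone, it remains open what the hydroxyl at the end of the 4-hydroxybut-1-yn-1-yl chain contributes, which a matching chain ending in an amine or a carboxylic acid would help to settle. Also open, as far as these compounds go, is whether the low number of compound 1 belongs to isopropyl alone or extends to other branched alkyl groups, such as tert-butyl, on this same chain carbon.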